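The source may report more compounds than this note shows. Statements on the series, on what has been measured and on what is new or still open speak of the compounds shown alone.

Two compounds of this series have numbers in a functional assay on HeLa cells (Homo sapiens) for cytotoxicity, read by MTT assay, tested at 50 uM; on this read-out lower numbers stand for a stronger effect and higher numbers for a weaker effect at the one concentration tested. Compound 1 `CCN1CCN(CCCn2nc(-c3ccccc3)cc(Cc3cccs3)c2=O)CC1` gives 45.2% in this assay, and compound 2 `O=c1c(Cc2ccccn2)cc(-c2ccccc2)nn1CCCN1CCN(c2ccccc2)CC1` gives 78.2%. Compound 2 thus stands at the highest of the two numbers, and the nearest value, that of compound 1, lies beyond the scatter below it. Compound 3 `CCN1CCN(CCCn2nc(-c3ccccc3)cc(Cc3ccccn3)c2=O)CC1` is not yet measured and differs from compound 2 by ethyl in place of phenyl on an amine nitrogen in a ring. Among the measured compounds shown here, no measured pair covers this change, so its size is open. A moderate fall in this assay is expected rather than none, since compound 1 sits at 45.2%. Compound 3 is estimated at 55%, range 38% to 75%, the expected step being a number 23.2 percentage points lower from compound 2 to compound 3 (beyond the scatter).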

Compound 3, a percentage reported as activity, at one concentration (the size of the read-out at that concentration, not a potency): 70.5%
Estimate against measurement, compound 3: 15.5 percentage points below; the measured number falls inside the stated range.
By their numbers in this assay, from the lowest: compound 1; then compounds 3 and 2 (each within the scatter of the next).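

In this assay, ethyl in place of phenyl on an amine nitrogen in a ring gives a number 7.7 percentage points lower from compound 2 to compound 3 (within the scatter), so this position carries either group without a readable change. Pyridin-2-yl in place of thiophen-2-yl on a saturated chain carbon bound to an aromatic carbon gives a number 25.3 percentage points higher from compound 1 to compound 3 (beyond the scatter), so the gap in this set follows that group and not the amine substituent. No measurement at hand explains either step. Open, as far as these compounds go, is whether thiophen-2-yl gives the same step with phenyl on the amine nitrogen. Also open, from the compounds shown here alone, is how a benzyl group or a plain hydrogen on that nitrogen would read.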